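The source may hold more compounds than are shown below. What is called first, only, known or untested is meant among the compounds shown, and "the series" means these compounds.

Measured compounds:
compound 1 `O=C(N/N=C/c1ccc(F)cc1F)c1cc(-c2ccc(Cl)cc2)nn1Cc1ccc(Cl)nc1` — 7860 nM
compound 2 `N=C(NO)c1cc(-c2ccc(Cl)cc2)nn1Cc1ccc(Cl)nc1` — 27900 nM

Both values come from a functional assay on NCI-H23 cells (Homo sapiens) for antiproliferative activity, read by BrdU incorporation, with a stated time of 48 h; a higher number here means a weaker inhibitor, a lower number a stronger inhibitor. Of the two numbers, compound 1 stands lowest; compound 2 gives a higher number, and the gap between them is beyond the scatter, so compound 1 is the stronger inhibitor of the pair. Compound 3 `O=C(N/N=C/c1ccccc1O)c1cc(-c2ccc(Cl)cc2)nn1Cc1ccc(Cl)nc1` has not yet been measured in this assay. It differs from compound 1 in a single place: 2-hydroxyphenyl in place of 2,4-difluorophenyl on a carbon with a double bond to nitrogen. The shared core and the remainder of compound 1 are untouched. Within the data shown here, no measured pair shows a step of this kind, so neither its sign nor its size can be read from the numbers at hand. The step of a 1.2-fold lower number from compound 1 to compound 3 (0.08 log units; within the scatter) is expected to be modest and may well stay within the scatter, in either direction. For compound 3 the estimate in this assay is 6500 nM, with a range from 2200 nM to 20000 nM.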

Compound 3, half-maximal inhibitory concentration: 270 nM
For compound 3 the middle estimate is 24-fold (1.38 log units) above the measured one, outside the stated range (below it).
By their numbers in this assay, from the lowest: compound 3; then compound 1; then compound 2.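

The aryl group on the carbon with a double bond to nitrogen is far from silent in this assay: 2-hydroxyphenyl in place of 2,4-difluorophenyl gives a 29-fold lower number from compound 1 to compound 3 (1.46 log units; beyond the scatter) with the shared core and the remainder of compound 1 untouched. Among these compounds, this is the first one-place step, and it shows that this position alone can move the antiproliferative read-out by a large margin. Nothing at hand accounts for the size of this step.

Going by these compounds, compound 3 gains the hydroxyl and loses both fluorines in one change, so the contribution of each remains open. An unsubstituted phenyl, 2-methoxyphenyl or 2-aminophenyl at the same place would help separate these contributions and test whether the hydroxyl itself is needed.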